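Cytotoxicity read-out: nitro in place of hydroxy

This account rests on a few compounds, and the source may have more. Where it says the series, first, only, none or still open, it means among the compounds named here.

Measured in an ADME assay on J774 cells (Mus musculus) for cytotoxicity, read by MTT assay, with a stated time of 48 h, tested at 150 ug/mL; on this read-out lower numbers stand for a stronger effect and higher numbers for a weaker effect at the one concentration tested:
compound 1, `O=C(N/N=C/c1cccc(F)c1)c1cnccn1`, gives 40%
compound 2, `O=C(N/N=C/c1cccc(Br)c1)c1cnccn1`, gives 93%
compound 3, `O=C(N/N=C/c1cccc(O)c1)c1cnccn1`, gives 88%

Compound 3 holds the second highest of the three numbers. One of the other two lies within the scatter of it: a number 5 percentage points lower from compound 2 to compound 3 (within the scatter). The other lies well apart: a number 48 percentage points higher from compound 1 to compound 3 (beyond the scatter).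

The next compound, compound 4, `O=C(N/N=C/c1cccc([N+](=O)[O-])c1)c1cnccn1`, differs from compound 3 in one place: nitro in place of hydroxy on an aromatic carbon.

Among the measured compounds shown here, the steps that bear on this change are those that vary the same aromatic carbon. Two of them are large and point the same way: a number 53 percentage points higher from compound 1 to compound 2 (beyond the scatter) and a number 48 percentage points higher from compound 1 to compound 3 (beyond the scatter). The third is flat: a number 5 percentage points lower from compound 2 to compound 3 (within the scatter). For the measured compounds named here, two of the three groups tried there therefore give high numbers and one gives a low one, and no measured step involves nitro itself, so the direction is not fixed by the data.

In this assay compound 4 is expected to lie close to compound 3, with the step of a number 8 percentage points lower from compound 3 to compound 4 (within the scatter) estimated to stay within the scatter. The estimate for compound 4 is 80%, with a range from 45% to 100%, the low end kept wide because compound 1 gives 40% at this same position.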

Compound 4, a percentage reported as activity, at one concentration (the size of the read-out at that concentration, not a potency): 76%
The estimate for compound 4 lay 4 percentage points above the measured number; measured number inside the range.
By their numbers in this assay, from the lowest: compound 1; then compound 4; then compounds 3 and 2 (each within the scatter of the next).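

In this assay nitro on this aromatic carbon separates from both earlier high-number groups, with a number 12 percentage points lower from compound 3 to compound 4 (beyond the scatter) and a number 17 percentage points lower from compound 2 to compound 4 (beyond the scatter), yet it stays far from the fluoro compound, with a number 36 percentage points higher from compound 1 to compound 4 (beyond the scatter) as the widest of the new steps. The position therefore shows three levels instead of the two seen before: fluoro lowest, nitro in the middle, and bromo and hydroxy together within the scatter of each other. The series offers no measured information that accounts for this ordering.

Going by these compounds, whether the low number is particular to fluoro remains open, and chloro, an amine, a carboxylic acid or a methoxy group on the same carbon would show whether other groups fall at the fluoro level, the nitro level or the bromo and hydroxy level. With one concentration per compound, the four numbers also leave open how the three levels would compare across a range of concentrations, and whether the order would hold with the same groups on another carbon of this ring.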